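Cytotoxicity notes on the oxazolidinone series: compound 4

The source may hold more compounds than are shown below. What is called first, only, known or untested is meant among the compounds shown, and "the series" means these compounds.

In an ADME assay on L02 cells (Homo sapiens) for cytotoxicity, read by MTT assay, with a stated time of 48 h (a lower number here means a stronger inhibitor, a higher number a weaker inhibitor), compound 2 (`O=C1CCC(=O)N1C[C@H]1CN(c2ccc(-n3cc(-c4ccccn4)cn3)c(F)c2)C(=O)O1`) gives only a limit, > 400 ug/mL. Compound 1 (`O=C1O[C@@H](CN2CCC(O)CC2)CN1c1ccc(-n2cc(-c3ccccn3)cn2)c(F)c1`) likewise gives only a limit in this assay, > 400 ug/mL. Compound 3 (`O=C(OC[C@H]1CN(c2ccc(-n3cc(-c4ccccn4)cn3)c(F)c2)C(=O)O1)c1ccccc1`) also gives only a limit in this assay, > 400 ug/mL. All three measured values therefore sit at the limit of > 400 ug/mL in this assay, at which 3 of the 3 values shown sit, and compound 2 stands on the same limit as the other two, with no number of its own to place it higher or lower.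

Compound 4 (`CCC(=O)NC[C@H]1CN(c2ccc(-n3cc(-c4ccccn4)cn3)c(F)c2)C(=O)O1`) differs from compound 2 by propanoylamino in place of 2,5-dioxopyrrolidin-1-yl on a saturated chain carbon bound to a saturated ring carbon.

The measured steps that touch the same place are a step that the two limits leave unreadable from compound 2 to compound 3 and a step that the two limits leave unreadable from compound 1 to compound 2; the third, a step that the two limits leave unreadable from compound 1 to compound 3, is equally unreadable. None of them gives a size or a direction, so nothing measured here favours a change in this assay beyond the scatter for compound 4. The step from compound 2 to compound 4 is therefore expected to read as a number no higher from compound 2 to compound 4 (the limit leaves the size open), most likely as another limit rather than a number.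

For compound 4 the expected value in this assay is 400 ug/mL, with a range from 200 ug/mL to 800 ug/mL.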

Compound 4, half-maximal inhibitory concentration: 204 ug/mL
For compound 4 the middle estimate is 2.0-fold (0.29 log units) above the measured one; the measured number falls inside the stated range.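

In this assay, compound 4 is the only compound shown with a number at this saturated chain carbon bound to a saturated ring carbon, and the other three remain limits: the limit of > 400 ug/mL in this assay, at which 3 of the 4 values shown sit.

Propanoylamino therefore gives the first readable steps at this place, as an at least 1.9-fold lower number from compound 2 to compound 4 (0.29 log units; that floor lies within the scatter), as an at least 1.9-fold lower number from compound 3 to compound 4 (0.29 log units; that floor lies within the scatter) and as an at least 1.9-fold lower number from compound 1 to compound 4 (0.29 log units; that floor lies within the scatter). Going by these compounds, each of these is only a floor within the scatter, so their true sizes remain unknown, and the steps among compound 1, compound 2 and compound 3 cannot be read.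

The change from compound 2 to compound 4 removes a five-membered non-aromatic ring and also adds a hydrogen-bond donor, and this single step does not separate those two differences. On these data alone, it also remains open whether acetylamino, butanoylamino or a free amine on the same chain carbon would give a number close to that of compound 4 or return to the limit.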